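Restoring a Sulfur Chain on a Weak Thiol Analogue

The source may report more compounds than this note shows. Statements on the series, on what has been measured and on what is new or still open speak of the compounds shown alone.

Compound 1, `CC(C)c1n[nH]c2c(NCc3ccc(-c4ccccn4)cc3)nc(SCCC(N)=O)nc12`: 120 nM
Compound 2, `CC(C)c1n[nH]c2c(NCc3ccc(-c4ccccn4)cc3)nc(SC[C@H](O)CN)nc12`: 63 nM
Compound 3, `CC(C)c1n[nH]c2c(NCc3ccc(-c4ccccn4)cc3)nc(S)nc12`: 2760 nM
Compound 4, `CC(C)c1n[nH]c2c(NCc3ccc(-c4ccccn4)cc3)nc(SCC(C)(C)N)nc12`: not yet measured

In a functional assay on HT cells (Homo sapiens) for antiproliferative activity, read by fluorescence, with a stated time of 72 h (on this read-out lower numbers stand for stronger inhibition of growth and higher numbers for weaker inhibition of growth), compound 3 gives 2760 nM, the highest of the three numbers, with compound 1 the nearer of the other two and compound 2 the further off. Compound 4 differs from compound 3 in one place: 2-amino-2-methylpropyl in place of hydrogen on a sulfur. Going by the values given here, two measured steps bear on this change, both running the opposite way: a 23-fold higher number from compound 1 to compound 3 (1.36 log units; beyond the scatter) and a 44-fold higher number from compound 2 to compound 3 (1.64 log units; beyond the scatter). In each, the sulfur of compound 3 left bare stood far beyond the scatter from a sulfur carrying a chain, and the chain of compound 2, which like the entering group contains an amine, gave the larger of the two gaps. The step to compound 4 puts a chain back on that sulfur, so a large fall in the number is expected, of roughly the size seen in those two steps. The expected step is a 35-fold lower number from compound 3 to compound 4 (1.54 log units; beyond the scatter). Compound 4 is therefore estimated at 80 nM, within a range from 30 nM to 250 nM.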

Compound 4, concentration for 50% growth inhibition: 85 nM
For compound 4 the middle estimate is 1.1-fold (0.03 log units) below the measured one; measured number inside the range.
By their numbers in this assay, from the lowest: compounds 2, 4 and 1 (each within the scatter of the next); then compound 3.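

In this assay a third chain on the sulfur, 2-amino-2-methylpropyl, gives a 32-fold lower number from compound 3 to compound 4 (1.51 log units; beyond the scatter) and so again stands far beyond the scatter from the bare thiol. Set against the two earlier chains it shows a 1.3-fold higher number from compound 2 to compound 4 (0.13 log units; within the scatter) and a 1.4-fold lower number from compound 1 to compound 4 (0.15 log units; within the scatter) and both lie within the scatter, so across these three chains neither the hydroxyl of compound 2 nor the amide of compound 1 is required to stay at this level. Nothing given here explains why a chain on this sulfur matters or why these three chains read alike.

On these data alone, it remains open whether any nitrogen in the chain is needed at all, as a plain propyl chain on the sulfur would test. Also open, as far as these compounds go, is how a carboxylic acid at the chain end or a longer chain carrying an amine would read.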